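Working notes: chloro in place of methyl on compound 2

A few compounds are considered here, and "the series" means these few. Any claim that something is new, unique, unknown or untested is made for them only; others in the source may bear on it.

Values measured so far in a functional assay (Homo sapiens) for antiproliferative activity (a lower number here means a stronger inhibitor of growth, a higher number a weaker inhibitor of growth), are as follows
- compound 1 `Cc1cn2c(/C=N/NC(=N)N)c(-c3ccncc3)nc2s1` gives 47900 nM
- compound 2 `Cc1cn2c(/C=N/NC(=N)N)c(-c3cccnc3)nc2s1` gives 22400 nM
- compound 3 `Cc1sc2nc(-c3ccccn3)c(/C=N/NC(=N)N)n2c1C` gives 41700 nM

Compound 2 stands beyond the scatter of compound 1 and within the scatter of compound 3, so all three values sit close together. Within the data shown here, the only measured step that changes a single place is a 2.1-fold lower number from compound 1 to compound 2 (0.33 log units; beyond the scatter) and it is modest, only just past the scatter. It concerns pyridin-3-yl in place of pyridin-4-yl, not the place that changes next.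

The next compound is compound 4 `N=C(N)N/N=C/c1c(-c2cccnc2)nc2sc(Cl)cn12` and the change from compound 2 is chloro in place of methyl on an aromatic carbon on an aromatic carbon next to the ring sulfur. Among the measured compounds shown here, no measured step touches that carbon, so the data give no direction for chloro in place of methyl. For the measured compounds named here, the modest size of a 2.1-fold lower number from compound 1 to compound 2 (0.33 log units; beyond the scatter) in this set serves as the only guide to scale. In this assay no shift beyond the scatter is therefore expected, and the estimated step is a 1.1-fold lower number from compound 2 to compound 4 (0.03 log units; within the scatter) with little weight on its direction. For compound 4 the estimate is 21000 nM with an expected range from 8000 nM to 55000 nM in this read-out.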

Compound 4, concentration for total growth inhibition: 46800 nM
Beside the measured number, compound 4's estimate is 2.2-fold (0.35 log units) below it; measured number inside the range.
By their numbers in this assay, from the lowest: compounds 2, 3, 4 and 1 (each within the scatter of the next, the first and the last beyond it).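

At the aromatic carbon next to the ring sulfur, chloro in place of methyl gives a 2.1-fold higher number from compound 2 to compound 4 (0.32 log units; beyond the scatter) in this assay, so this position responds to a swap that leaves the counts of hydrogen-bond donors and acceptors unchanged. The step is modest, as is a 2.1-fold lower number from compound 1 to compound 2 (0.33 log units; beyond the scatter), but it lies at a different place and runs towards a weaker inhibitor of growth, so methyl is the better of these two groups on the core of compound 2. Nothing available explains the shift, and no measured property of either group bears on it.

The compounds shown leave open whether this carbon prefers methyl specifically or simply disfavours chloro, a question that hydrogen, bromo, ethyl, methoxy or an amine at the same carbon would help to settle. They also leave open whether the chloro step carries over with pyridin-4-yl in place of pyridin-3-yl, since only the pyridin-3-yl pair has been compared at this position.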